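A methoxy group added to the core of compound 1

This account rests on a few compounds, and the source may have more. Where it says the series, first, only, none or still open, it means among the compounds named here.

Compound 1 `Cn1cc(C2CC(c3ccccc3)=NN2C(=O)c2cccnc2)c2ccccc21`: > 10000 nM (a limit)
Compound 2 `COc1ccc(C(=O)N2N=C(c3ccccc3)CC2c2cn(C)c3ccccc23)cn1`: 3040 nM
Compound 3 `Cn1cc(C2CC(c3ccccc3)=NN2C(=O)c2cccnc2Cl)c2ccccc21`: > 10000 nM (a limit)

In a functional assay on A549 cells (Homo sapiens) for inhibition, read by MTT assay, with a stated time of 48 h (a higher number here means a weaker inhibitor of growth, a lower number a stronger inhibitor of growth), compound 1 gives > 10000 nM, which is a limit and not a number. Compound 1 thus stands at the limit of > 10000 nM in this assay, at which 2 of the 3 values shown sit.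

Compound 4 `COc1ccc2c(c1)c(C1CC(c3ccccc3)=NN1C(=O)c1cccnc1)cn2C` differs from compound 1 by one change: methoxy in place of hydrogen on an aromatic carbon. The closest measured change is also methoxy in place of hydrogen, and it gives an at least 3.2-fold lower number from compound 1 to compound 2 (0.51 log units; beyond the scatter). There the methoxy forms the 6-methoxypyridin-3-yl group on the carbonyl carbon, whereas in compound 4 it sits on the six-membered aromatic ring of carbon only, so that step is a loose guide. The chloro exchange gives a step that the two limits leave unreadable from compound 1 to compound 3 and says nothing about size. Within the data shown here, the remaining step, an at least 3.2-fold higher number from compound 2 to compound 3 (0.51 log units; beyond the scatter), again sets compound 2 apart as the only compound with a readable number.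

A modest drop in the number is therefore expected, though compound 4 may well stay at the limit. The step expected is an at least 1.4-fold lower number from compound 1 to compound 4 (0.15 log units; that floor lies within the scatter). For compound 4 the estimated value is 7000 nM, with an expected range from 2000 nM to 20000 nM.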

Compound 4, concentration for 50% growth inhibition: > 10000 nM
Compound 4 was reported as a limit (the forecaster's own chance of this, stated with the estimate: 45%); middle value at least 1.4-fold (0.15 log units) away from the limit.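

In this assay compound 4 gives > 10000 nM, which is a limit and not a number. Among these compounds, compound 1 is also reported only as a limit, so no step between compound 1 and compound 4 can be read: the limit of > 10000 nM in this assay, at which 3 of the 4 values shown sit. The compounds shown leave open whether methoxy on the six-membered aromatic ring of carbon only changes growth inhibition at all.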